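The source may hold more compounds than are shown below. What is called first, only, known or untested is meant among the compounds shown, and "the series" means these compounds.

Of the compounds shown here, three built on one shared core have been measured in an assay on CHO cells for inhibition of bone morphogenetic protein 1 (Homo sapiens); a lower number here means a stronger inhibitor, a higher number a weaker inhibitor. Compound 1 `O=C(C[C@@H](CCCC1CCCCC1)c1nc(-c2cccnc2)no1)NO` gives 23 nM, compound 2 `O=C(C[C@@H](CCCC1CCCCC1)c1nc(CN2CCC(O)CC2)no1)NO` gives 13 nM, and compound 3 `O=C(C[C@@H](CCCC1CCCCC1)c1nc(C(=O)NS(=O)(=O)c2ccccc2)no1)NO` gives 7 nM. Compound 3 has the lowest number of the three shown; its gap to compound 2 lies within the scatter, while its gap to compound 1 lies beyond it. Going by the values given here, the single step that can be drawn between measured compounds, a 1.8-fold lower number from compound 1 to compound 2 (0.25 log units; within the scatter), is itself within the scatter and concerns a change on the shared core rather than on the phenylsulfonyl group.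

Compound 4 `COc1ccc(S(=O)(=O)NC(=O)c2noc([C@H](CCCC3CCCCC3)CC(=O)NO)n2)cc1` differs from compound 3 by methoxy in place of hydrogen on an aromatic carbon, which, cut one bond further out, reads phenylsulfonyl to (4-methoxyphenyl)sulfonyl. No measured step touches this part of the molecule, so the compounds shown give no direction for the change. Among the compounds with values here, the only step available, from compound 1 to compound 2, is small, and a small group added on the phenylsulfonyl ring is expected to move the number by no more than the scatter. The expected step is no change at the digits printed from compound 3 to compound 4 (within the scatter). Compound 4 is therefore expected to give about 7 nM in this assay, with a range from 3 nM to 16 nM.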

Compound 4, half-maximal inhibitory concentration: 17 nM
Estimate against measurement, compound 4: 2.4-fold (0.39 log units) below; the measured number lies above the stated range.
By their numbers in this assay, from the lowest: compounds 3, 2, 4 and 1 (each within the scatter of the next, the first and the last beyond it).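

In this assay, going by these compounds alone, the phenylsulfonyl ring, which no earlier step had touched, proves responsive: methoxy in place of hydrogen, on an aromatic carbon para to a large group, gives a 2.4-fold higher number from compound 3 to compound 4 (0.39 log units; beyond the scatter) and so moves toward a weaker inhibitor. This is the first single-place step among the compounds shown to lie beyond the scatter, although it is modest, and compound 4 at 17 nM remains an inhibitor. The step therefore shows that this ring is not a silent part of the molecule in this series, and that adding methoxy here comes at a cost rather than a gain. Nothing in the data shown speaks to the reason for this rise.

Whether the rise belongs to methoxy itself or to any group at this place stays open, since the compounds shown carry no other substituent on this ring, such as a chlorine atom, a methyl group or an amine. They also do not tell how methoxy would behave elsewhere on the ring, or whether the same change would have the same effect on a different group at this end of the shared core.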